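Benzoyl aryl series: chloro to methyl swap, cytotoxicity notes

A few compounds are considered here, and "the series" means these few. Any claim that something is new, unique, unknown or untested is made for them only; others in the source may bear on it.

Measured in an ADME assay on NIH3T3 cells (Mus musculus) for cytotoxicity, read by LDH release, with a stated time of 48 h; on this read-out higher numbers stand for weaker inhibition and lower numbers for stronger inhibition:
- compound 1 `Cn1cnc(C(=O)NNC(=O)COc2c(F)cc(C(=O)c3ccc(F)cc3)cc2Cl)c1`: 94400 nM
- compound 2 `Cn1cnc(C(=O)NNC(=O)COc2c(F)cc(C(=O)c3ccc(Cl)cc3)cc2Cl)c1`: 89300 nM

Among the compounds with values here, compound 2, at 89300 nM, cannot be separated from the only other measured compound. Next is compound 3 `Cc1ccc(C(=O)c2cc(F)c(OCC(=O)NNC(=O)c3cn(C)cn3)c(Cl)c2)cc1`, with this change: methyl in place of chloro on an aromatic carbon. It puts methyl in place of chloro on an aromatic carbon, para to a large group. Within the data shown here, one measured step bears on it, at the same carbon: a 1.1-fold lower number from compound 1 to compound 2 (0.02 log units; within the scatter). Among the measured compounds shown here, no methyl compound has been measured, so that small step is a limited guide, and no step beyond the scatter is expected in this assay. The estimated step is a 1.0-fold higher number from compound 2 to compound 3 (0.00 log units; within the scatter). For compound 3 the expected value is 90000 nM, with an estimated range of 50000 nM to 160000 nM.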

Compound 3, half-maximal inhibitory concentration: 94900 nM
For compound 3 the middle estimate is 1.1-fold (0.02 log units) below the measured one; measured number inside the range.
By their numbers in this assay, from the lowest: compounds 2, 1 and 3 (each within the scatter of the next).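

In this assay methyl in place of chloro gives a 1.1-fold higher number from compound 2 to compound 3 (0.03 log units; within the scatter) and methyl in place of fluoro gives a 1.0-fold higher number from compound 1 to compound 3 (0.00 log units; within the scatter) on the same aromatic carbon. The earlier pair covered only two halogens, whereas this carbon now also carries a non-halogen group with no separation among the three compounds. No available evidence explains this flat result.

From the compounds shown here alone, whether an amine, a carboxylic acid or a longer chain at this carbon would stay within the scatter remains open. The compounds shown also leave open how changes elsewhere on the shared core would read.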